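Aryl swap on the thiophene carbon of the shared core

The source may hold more compounds than are shown below. What is called first, only, known or untested is meant among the compounds shown, and "the series" means these compounds.

Among the compounds with values here, compound 1, `CC#C[C@@H](Cc1nnn[nH]1)c1ccc(OCc2ccc3scc(-c4cncnc4C)c3c2)cc1`, is the only member with a number in an ADME assay on microsomes from liver (Rattus norvegicus) for metabolic stability (on this read-out lower numbers stand for a shorter-lived compound and higher numbers for a longer-lived compound), where compound 1 gives 0.333 h. Compound 2, `CC#C[C@@H](Cc1nnn[nH]1)c1ccc(OCc2cc(C)c3scc(-c4ccccc4C)c3c2)cc1`, differs from compound 1 in more than one place, and in this assay compound 2 reaches only a limit, < 0.0667 h. Compound 3, `CC#C[C@@H](Cc1nnn[nH]1)c1ccc(OCc2ccc3scc(-c4ccc(OCCOC)cc4C)c3c2)cc1`, is not yet measured; it differs from compound 1 by 4-(2-methoxyethoxy)-2-methylphenyl in place of 4-methylpyrimidin-5-yl on an aromatic carbon. Within the data shown here, with no single-point step known, the expected step of a 2.8-fold lower number from compound 1 to compound 3 (0.44 log units; beyond the scatter) is downward and beyond the usual scatter. Compound 3 is estimated at 0.12 h, within 0.05 h to 0.3 h.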

Compound 3, half-life: 0.217 h
Compound 3: middle estimate off by 1.8-fold (0.26 log units), on the low side; measured number inside the range.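

At this position, on an aromatic carbon two ring bonds from the ring sulfur, this assay shows a 1.5-fold lower number from compound 1 to compound 3 (0.19 log units; within the scatter). Within the data shown here, this is the first single-place comparison: on this read-out, 4-(2-methoxyethoxy)-2-methylphenyl and 4-methylpyrimidin-5-yl do not separate. Nothing measured here bears on a cause for this step.

Among these compounds, compound 2 gives only a limit, < 0.0667 h, and differs from compound 1 in more than one place, so it supplies no step. From the compounds shown here alone, whether an amine, a carboxylic acid or a longer chain on this aromatic ring would move the half-life beyond the scatter remains open.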